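Chloro for hydrogen on the shared core: cytotoxicity

A few compounds are considered here, and "the series" means these few. Any claim that something is new, unique, unknown or untested is made for them only; others in the source may bear on it.

Compound 1, `CCCc1c(Cl)c(O)c(Cl)c(OC)c1Oc1c(Cl)c(O)c(Cl)c2c1C(=O)O[C@@H]2CC`: > 100000 nM
Compound 2, `CCCc1cc(O)c(Cl)c(O)c1Oc1c(Cl)c(O)c(Cl)c2c1C(=O)O[C@@H]2CC`: > 100000 nM
Compound 3, `CCCc1cc(O)cc(OC)c1Oc1c(Cl)c(O)c(Cl)c2c1C(=O)O[C@@H]2CC`: > 100000 nM

In an ADME assay on MDCK cells (Canis lupus familiaris) for cytotoxicity, read by CellTiter-Glo, with a stated time of 40 h (a lower number here means that less compound is tolerated, a higher number that more compound is tolerated), compound 3 gives only a limit, > 100000 nM, and not a number. Among the measured compounds shown here, compound 1 and compound 2 likewise stand at limits, so that the limit of > 100000 nM in this assay, at which 3 of the 3 values shown sit, describes the whole set and no compound stands apart from the others. For the measured compounds named here, there is thus no measured step on which a direction could be read.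

Compound 4, `CCCc1cc(O)c(Cl)c(OC)c1Oc1c(Cl)c(O)c(Cl)c2c1C(=O)O[C@@H]2CC`, differs from compound 3 by chloro in place of hydrogen on an aromatic carbon. With every shown value sitting at the limit, the step that the limit leaves unreadable from compound 3 to compound 4 is expected to be none beyond the usual scatter. Compound 4 is therefore estimated at 150000 nM, within a range from 60000 nM to 400000 nM, and will most probably again be reported only as a limit in this assay.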

Compound 4, half-maximal cytotoxic concentration: > 100000 nM
Compound 4: a limit, no number; the forecaster's own chance of this, stated with the estimate: 85%; the middle value is on the limit's open side.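

In this assay compound 4 gives > 100000 nM, a limit and not a number. Its steps from compound 1, compound 2 and compound 3 cannot be read: the limit of > 100000 nM in this assay, at which 4 of the 4 values shown sit.

The compounds shown leave open what the actual half-maximal cytotoxic concentration of any of the four is, and whether chloro in place of hydrogen shifts it at all.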